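Cytotoxicity limits in the ester series, vinyl to acetyl

A few compounds are considered here, and "the series" means these few. Any claim that something is new, unique, unknown or untested is made for them only; others in the source may bear on it.

Measured so far:
Compound 1 `C=Cc1cccc(-c2[nH]c3cc(OC)ccc3c(=O)c2C(=O)OCC)c1`; in an ADME assay on BJ cells (Homo sapiens) for cytotoxicity, read by luminescence, with a stated time of 72 h (on this read-out higher numbers stand for an effect only at larger amounts of compound and lower numbers for an effect already at smaller amounts), compound 1 gives > 21500 nM, which is a limit of the assay and not a number.
Compound 2 `CCOC(=O)c1c(-c2cccc(OCc3ccccc3)c2)[nH]c2cc(OC)ccc2c1=O`; in this assay compound 2 gives > 21500 nM, again a limit.
Compound 3 `CCOC(=O)c1c(-c2cccc(Cl)c2)[nH]c2cc(OC)ccc2c1=O`; in this assay compound 3 gives > 21500 nM, again a limit.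

Compound 1 therefore stands at the limit of this assay, and no ranking among the three is possible, since all three sit at the same limit (the limit of > 21500 nM in this assay, at which 3 of the 3 values shown sit). The steps between them, a step that the two limits leave unreadable from compound 1 to compound 2, a step that the two limits leave unreadable from compound 1 to compound 3 and a step that the two limits leave unreadable from compound 2 to compound 3, are each of a size that the two limits leave unreadable.

The next compound, compound 4 `CCOC(=O)c1c(-c2cccc(C(C)=O)c2)[nH]c2cc(OC)ccc2c1=O`, differs from compound 1 by acetyl in place of vinyl on an aromatic carbon.

For the measured compounds named here, none of the measured steps gives a readable size, so no direction beyond the scatter can be drawn from them for this change. What the three compounds do show is that changes at the same aromatic carbon have so far left every compound at the limit (the limit of > 21500 nM in this assay, at which 3 of the 3 values shown sit). Compound 4 is therefore expected to sit at that limit as well, with a step that the limit leaves unreadable from compound 1 to compound 4 read as an expected step of no measurable size. The estimate for compound 4 in this assay is 30000 nM, expected between 15000 nM and 100000 nM.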

Compound 4, half-maximal effective concentration: > 21500 nM
Compound 4: only a limit was reported; the forecaster's own chance of this, stated with the estimate: 85%; the middle value does not contradict the limit.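

In this assay compound 4 gives > 21500 nM as a limit of the assay and not a number. For the compounds shown here, no step from compound 4 to compound 1, compound 2 or compound 3 can be read, since all four sit at one limit: the limit of > 21500 nM in this assay, at which 4 of the 4 values shown sit. Still open, on these data alone, is whether in this assay any change at this aromatic carbon gives a value that is a number and not a limit.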